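The source may hold more compounds than are shown below. What is called first, only, known or untested is meant among the compounds shown, and "the series" means these compounds.

Compound 1 `COc1cc(OC)c(OC)cc1/C=C/C(=O)c1ccc(O)cc1O` and compound 2 `COc1cc(OC)c(OC)cc1/C=C/C(=O)c1ccc(C)cc1` share one core and differ only in the group on the carbonyl carbon. In a functional assay on HeLa cells (Homo sapiens) for inhibition, read by MTT assay, with a stated time of 72 h (on this read-out higher numbers stand for weaker inhibition and lower numbers for stronger inhibition), compound 1 gives 37600 nM and compound 2 gives 42200 nM. These two numbers lie within the usual scatter of each other, so compound 2 stands level with compound 1.

Compound 3 `COc1cc(OC)c(OC)cc1/C=C/C(=O)c1cc(O)ccc1O` has not yet been measured. It has 2,5-dihydroxyphenyl in place of the 4-methylphenyl of compound 2 on the carbonyl carbon: 2,5-dihydroxyphenyl in place of 4-methylphenyl on a carbonyl carbon. Within the data shown here, one measured step bears on this change, the swap of 2,4-dihydroxyphenyl for 4-methylphenyl, which gave a 1.1-fold higher number from compound 1 to compound 2 (0.05 log units; within the scatter). Among the measured compounds shown here, no measured compound carries 2,5-dihydroxyphenyl, so this is only a guide, but it points to no step beyond the scatter in this assay. The estimated step is a 1.2-fold lower number from compound 2 to compound 3 (0.08 log units; within the scatter). The estimate for compound 3 is 35000 nM, with an expected range from 14000 nM to 70000 nM.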

Compound 3, half-maximal inhibitory concentration: > 150000 nM
Compound 3: a limit, no number (the forecaster's own chance of this, stated with the estimate: 5%); middle value at least 4.2-fold (0.63 log units) away from the limit.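

In this assay, compound 3 gives only a limit of the assay, not a number: the limit of > 150000 nM in this assay, at which 1 of the 3 values shown sits. The earlier pair suggested that the group on the carbonyl carbon could change without much effect, but this result shows otherwise, with an at least 3.5-fold higher number from compound 2 to compound 3 (0.55 log units; beyond the scatter) and an at least 3.9-fold higher number from compound 1 to compound 3 (0.60 log units; beyond the scatter). The second step is the more telling one, as 2,4-dihydroxyphenyl and 2,5-dihydroxyphenyl have the same atoms arranged differently, so at this place the arrangement of the hydroxyl groups separates compound 1 from compound 3, not merely their presence.

From the compounds shown here alone, how far compound 3 lies past its limit stays unknown. Also open, going by these compounds, is whether a 2,5-dimethoxyphenyl group or a 2,5-diaminophenyl group on the carbonyl carbon would behave like 2,5-dihydroxyphenyl.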